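The source may hold more compounds than are shown below. What is called first, only, known or untested is meant among the compounds shown, and "the series" means these compounds.

In an ADME assay on DG-75 cells (Homo sapiens) for cytotoxicity, read by MTT assay, with a stated time of 120 h (a higher number here means a weaker inhibitor, a lower number a stronger inhibitor), compound 1 `N#C[C@H]1[C@H](O)[C@@H](CO)O[C@H]1n1cnc2c(Cl)nc(N)nc21` gives > 15000 nM as a limit of the assay. Compound 2 `N#C[C@H]1[C@H](O)[C@@H](CO)O[C@H]1n1cnc2c(N)ncnc21` gives > 15000 nM which is likewise a limit and not a number. Both measured compounds stand at the limit of > 15000 nM in this assay, at which 2 of the 2 values shown sit, and no graded reading exists yet. Compound 3 `N#C[C@H]1[C@H](O)[C@@H](CO)O[C@H]1n1cnc2c(N)nc(N)nc21` differs from compound 2 by amino in place of hydrogen on an aromatic carbon with amino in place of hydrogen on an aromatic carbon, between two ring nitrogen atoms. Going by the values given here, no measured step covers this change, so the expected step that the limit leaves unreadable from compound 2 to compound 3 in this assay stays within the scatter. For compound 3 the estimated value is 18000 nM with an expected range of 7000 nM to 40000 nM and another report as a limit is likely.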

Compound 3, half-maximal inhibitory concentration: > 15000 nM
Compound 3 was reported as a limit; the forecaster's own chance of this, stated with the estimate: 85%; the middle value is on the limit's open side.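

No step can be read from compound 2 to compound 3 or from compound 1 to compound 3, because all three compounds share one limit and give no number: the limit of > 15000 nM in this assay, at which 3 of the 3 values shown sit.

The compounds shown leave open how these three compare in this assay, with no graded value among them.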